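Notes on a chain change from compound 1

The compounds below may be only part of what the source reports. "The series", "measured", "known", "first", "only" and "open" are said of these compounds alone.

Measured in a functional assay on SK-OV-3 cells (Homo sapiens) for cytotoxicity, read by MTT assay; a higher number here means a weaker inhibitor, a lower number a stronger inhibitor:
compound 1 `CCCCCCCCC1CC1CCCCCCCC(=O)OC[C@H](CO[C@@H]1O[C@H](CO)[C@@H](O)[C@H](O)[C@H]1O)OC(=O)CCCCCCCC1CC1CCCCCCCC` gives 113000 nM
compound 2 `C=CCCCCCCCCC(=O)OC[C@H](CO[C@@H]1O[C@H](CO)[C@@H](O)[C@H](O)[C@H]1O)OC(=O)CCCCCCCCC=C` gives 89600 nM

These two values lie within the usual scatter of each other, so compound 1 stands level with compound 2 and no order can be drawn between them. Both numbers are large for this read-out.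

Compound 3 `CCCCCCCC/C=C\CCCCCCCC(=O)O[C@H](COC(=O)CCCCCCCC1CC1CCCCCCCC)CO[C@@H]1O[C@H](CO)[C@@H](O)[C@H](O)[C@H]1O` has not yet been measured. The change is dec-1-en-1-yl in place of 2-octylcyclopropyl on a saturated chain carbon, seven bonds along the chain from a carbonyl carbon and it reads in words as dec-1-en-1-yl in place of 2-octylcyclopropyl on a saturated chain carbon, seven bonds along the chain from a carbonyl carbon. The rest of the core of compound 1 stays as it is.

No measured step sizes this change directly. In this assay no step beyond the scatter is expected, and no direction is favoured. That expectation rests only on compound 1 at 113000 nM and compound 2 at 89600 nM sitting close together. The expected step is a 1.1-fold lower number from compound 1 to compound 3 (0.05 log units; within the scatter) and it stays within the scatter. For compound 3 the estimated value is 100000 nM with an expected range from 45000 nM to 220000 nM (both ends estimated).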

Compound 3, half-maximal inhibitory concentration: 35600 nM
Beside the measured number, compound 3's estimate is 2.8-fold (0.45 log units) above it, and the stated range ends above it.
By their numbers in this assay, from the lowest: compound 3; then compounds 2 and 1 (each within the scatter of the next).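

In this assay, going by these compounds alone, the exchange of 2-octylcyclopropyl for dec-1-en-1-yl on a saturated chain carbon, seven bonds along the chain from a carbonyl carbon, gives a 3.2-fold lower number from compound 1 to compound 3 (0.50 log units; beyond the scatter) and is the first change in one place that can be sized, since compounds 1 and 2 differ in more than one place and stand level. The position therefore responds to this exchange, even though only one of the two chains is altered and the other keeps its 2-octylcyclopropyl group, while the shared core stays as it is. Even so, compound 3 at 35600 nM remains a large number for this read-out, and no measurement available here bears on what lies behind the step.

As far as these compounds go, whether the same exchange on the remaining chain would add a further step stays open. Also open, from the compounds shown here alone, is how this position would respond to a saturated decyl chain, a longer chain, or a chain carrying a carboxylic acid or an amine.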